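Primary Amide in Place of the tert-Butyl Ester

A few compounds are considered here, and "the series" means these few. Any claim that something is new, unique, unknown or untested is made for them only; others in the source may bear on it.

Compound 1 `CC1=C(C(=O)OC(C)(C)C)C(c2ccsc2)NC(=O)N1` stands lowest of the three measured compounds in an assay on membranes from HeLa cells for displacement of a labelled ligand from adenosine receptor A3 (Homo sapiens), read by scintillation counting, with a stated time of 180 min, tested at 1 uM (a lower number here means less inhibition, a higher number more inhibition at the concentration tested (going by the name of the read-out)), where compound 1 gives 1%. Compound 2 `CC1=C(C(=O)OCc2ccccc2)C(c2ccsc2)NC(=O)N1` gives 25%, and compound 3 `CC1=C(C(=O)OC(C)(C)C)C(c2ccsc2)NC(=O)N1C` gives 14%. Both measured steps point upward: a number 24 percentage points higher from compound 1 to compound 2 (beyond the scatter), with benzyl in place of tert-butyl on an oxygen next to a carbonyl group, and a number 13 percentage points higher from compound 1 to compound 3 (beyond the scatter), with methyl in place of hydrogen on an amide-type nitrogen in a ring. Compound 4 `CC1=C(C(N)=O)C(c2ccsc2)NC(=O)N1` differs from compound 1 by amino in place of tert-butoxy on a carbonyl carbon. Among the compounds with values here, only the step to compound 2 concerns the same carbonyl position, and no measured step tests an amino group there, so the expected step of a number 7 percentage points higher from compound 1 to compound 4 (within the scatter) is small, upward if anything, and close to the scatter. Compound 4 is therefore estimated at 8%, in the range 0% to 25%.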

Compound 4, a percentage reported as inhibition, at one concentration (the size of the read-out at that concentration, not a potency): 1%
The estimate for compound 4 lay 7 percentage points above the measured number; the range from low to high includes it.
By their numbers in this assay, from the lowest: compounds 1 and 4 (each within the scatter of the next); then compound 3; then compound 2.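

In this assay, amino in place of tert-butoxy on a carbonyl carbon gives no change at the digits printed from compound 1 to compound 4 (within the scatter). So losing tert-butoxy does not by itself raise the number at this position: benzyl on the oxygen in compound 2 does, while amino in compound 4 does not. Nothing shown here gives a reason for this result.

As far as these compounds go, whether an N-benzyl amide would behave like compound 2 or compound 4 remains open, as does a carboxylic acid at this carbonyl carbon. Also open, from the compounds shown here alone, is whether methyl on the ring nitrogen, as in compound 3, would raise the number for the primary amide.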